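This account rests on a few compounds, and the source may have more. Where it says the series, first, only, none or still open, it means among the compounds named here.

Compound 1 `COc1cc(CC(C)C(=O)N2CCN(c3ccc(C(F)(F)F)cc3[C@@H](N)CC(C)C)CC2)ccc1Cl` in an assay on HEK293 cells for displacement of a labelled ligand from Melanocortin receptor 4 (Homo sapiens) (a higher number here means a weaker inhibitor, a lower number a stronger inhibitor), gives 230 nM.
Compound 2 `CC(C)C[C@H](N)c1cc(C(F)(F)F)ccc1N1CCN(C(=O)CCC(=O)N(C)C)CC1` in this assay gives > 10000 nM, which is a limit of the assay and not a number.
Compound 3 `CC(C)C[C@H](N)c1cc(C(F)(F)F)ccc1N1CCN(C(=O)COc2cccc3ccccc23)CC1` in this assay gives 2600 nM.

Of the two actual numbers shown, compound 3 stands highest, that is, it is the weaker inhibitor; compound 1 is nearest to it, and the step is an 11-fold higher number from compound 1 to compound 3 (1.05 log units; beyond the scatter). The step of an at least 3.8-fold lower number from compound 2 to compound 3 (0.58 log units; beyond the scatter) is known only as a bound, with compound 2 sitting at the limit of > 10000 nM in this assay, at which 1 of the 3 values shown sits.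

Compound 4 `CC(C)C[C@H](N)c1cc(C(F)(F)F)ccc1N1CCN(C(=O)COc2cccc(Cl)c2)CC1` differs from compound 3 in one place: 3-chlorophenyl in place of naphthalen-1-yl on an oxygen on a saturated carbon. Going by the values given here, no measured step swaps one aromatic group for another on that oxygen. The two steps that touch this end of the molecule, an 11-fold higher number from compound 1 to compound 3 (1.05 log units; beyond the scatter) and an at least 3.8-fold lower number from compound 2 to compound 3 (0.58 log units; beyond the scatter), replace the whole group on the carbonyl carbon or on the chain carbon, and both are large. They show that this end matters, but they do not tell in which direction a smaller aromatic ring will move the number. A modest step is therefore expected in this assay for compound 4, a 1.7-fold higher number from compound 3 to compound 4 (0.24 log units; within the scatter), leaning toward a higher number. Compound 4 is estimated at 4500 nM, between 1500 nM and 14000 nM.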

Compound 4, inhibition constant: 2600 nM
Compound 4: the middle estimate sits 1.7-fold (0.24 log units) above what was measured, and the stated range covers the measured number.
By their numbers in this assay, from the lowest: compound 1; then compounds 3 and 4 (each within the scatter of the next). At a limit, above all of these: compound 2.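

In this assay, the step of no change at the digits printed from compound 3 to compound 4 (within the scatter) shows that 3-chlorophenyl can take the place of naphthalen-1-yl on this oxygen, one aromatic ring for two and fewer heavy atoms, without a change beyond the scatter. Neither group closes the gap to the group on the carbonyl carbon of the core of compound 1, as the step of an 11-fold higher number from compound 1 to compound 4 (1.05 log units; beyond the scatter) shows. The step of an at least 3.8-fold lower number from compound 2 to compound 4 (0.58 log units; beyond the scatter) is known only as a bound, as compound 2 stands at a limit and not at a number: the limit of > 10000 nM in this assay, at which 1 of the 4 values shown sits.

On these data alone, what the chlorine contributes stays open, and a plain phenyl on this oxygen would separate its part from that of the ring count. Also open, as far as these compounds go, is how a pyridine ring or a longer chain between the oxygen and the carbonyl would move the number.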